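The source may report more compounds than this note shows. Statements on the series, on what has been measured and on what is new or still open speak of the compounds shown alone.

Working notes on the series of bis(trifluoromethyl)benzenesulfonamides carrying a diamine chain.

Compound 1 `O=S(=O)(NCCCCNCc1ccc(Br)cc1)c1cc(C(F)(F)F)cc(C(F)(F)F)c1` gives 2000 nM in a functional assay on HPAC cells (Homo sapiens) for inhibition, read by MTT assay, with a stated time of 72 h; a lower number here means a stronger inhibitor of growth, a higher number a weaker inhibitor of growth. Compound 2 `O=S(=O)(NCCCNCc1ccc(Cl)c(Cl)c1)c1cc(C(F)(F)F)cc(C(F)(F)F)c1` gives 2500 nM in this assay, and compound 3 `O=S(=O)(NCCCNCC1COc2ccccc2O1)c1cc(C(F)(F)F)cc(C(F)(F)F)c1` gives 2700 nM. The three numbers sit close together: compound 3 holds the highest of them, with compound 2 nearest and compound 1 furthest, both gaps within the scatter.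

Two steps connect the measured compounds. The exchange of the aryl-methylamino end in a 1.3-fold higher number from compound 1 to compound 2 (0.10 log units; within the scatter) left the number essentially unchanged, and the replacement of the 3,4-dichlorophenyl by a 2,3-dihydro-1,4-benzodioxin-2-yl in a 1.1-fold higher number from compound 2 to compound 3 (0.03 log units; within the scatter) did likewise. Neither step rises above the scatter.

Compound 4 `O=S(=O)(NCCCNCc1ccccc1)c1cc(C(F)(F)F)cc(C(F)(F)F)c1` differs from compound 3 by phenyl in place of 2,3-dihydro-1,4-benzodioxin-2-yl on a saturated chain carbon bound to an amine nitrogen. This is the third variation of the group on the saturated chain carbon bound to the amine nitrogen, and the two earlier variations at that position moved the number by nothing beyond the scatter, so no step beyond the scatter is expected from compound 3 to compound 4 either, the expected change being a 1.1-fold higher number from compound 3 to compound 4 (0.05 log units; within the scatter). Compound 4 is accordingly estimated at 3000 nM in this assay, with a range from 1200 nM to 7500 nM.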

Compound 4, concentration for 50% growth inhibition: 3200 nM
Compound 4: the middle estimate sits 1.1-fold (0.03 log units) below what was measured; measured number inside the range.
By their numbers in this assay, from the lowest: compounds 1, 2, 3 and 4 (each within the scatter of the next).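

In this assay, compound 4 shows that the group on the saturated chain carbon bound to an amine nitrogen can be reduced to a bare phenyl without a step beyond the scatter: the non-aromatic ring and both of its oxygens, the hydrogen-bond acceptors of the leaving group, go in a 1.2-fold higher number from compound 3 to compound 4 (0.07 log units; within the scatter), and the two chlorines of compound 2 go in a 1.3-fold higher number from compound 2 to compound 4 (0.11 log units; within the scatter). The same holds when the comparison takes in the chain and the bromine of compound 1, in a 1.6-fold higher number from compound 1 to compound 4 (0.20 log units; within the scatter), so that among these four compounds neither the ring oxygens, nor the chlorines, nor the bromine separates one number from another. No measurement at hand bears on why these numbers stay together.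

Still open, from the compounds shown here alone, is whether any group at this position moves the number beyond the scatter, for example a phenyl carrying a carboxylic acid or a dimethylamino group, or a pyridine ring in place of the phenyl. Equally open, going by these compounds, is how the number responds to a longer chain between the two nitrogens, or to an amide in place of the amine.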